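Benzyl for Alkyl in a Nucleoside Amide Series

The source may hold more compounds than are shown below. What is called first, only, known or untested is meant among the compounds shown, and "the series" means these compounds.

The measured compounds:
compound 1 `CCCCCCCNC(=O)[C@H]1OC(n2cnc3c(N)ncnc32)[C@H](O)[C@@H]1O` with 20 nM
compound 2 `Nc1ncnc2c1ncn2C1O[C@H](C(=O)NC2CCCCCCC2)[C@@H](O)[C@H]1O` with 23 nM

Compound 1 gives the lower of the two numbers in an assay on cell membranes for binding affinity to 2-oxoglutarate receptor 1 (Rattus norvegicus), read by radioligand binding (a higher number here means a weaker inhibitor, a lower number a stronger inhibitor), and compound 2 is the nearest at a 1.2-fold higher number from compound 1 to compound 2 (0.06 log units; within the scatter), so the two cannot be ordered. That single step shows that the shared core accepts a cyclooctyl as well as a heptyl on the amide-type nitrogen without a change beyond the scatter.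

Compound 3 `COc1ccc(CNC(=O)[C@H]2OC(n3cnc4c(N)ncnc43)[C@H](O)[C@@H]2O)cc1OC` has not been measured in this assay. It differs from compound 1 by 3,4-dimethoxyphenyl in place of hexyl on a saturated chain carbon bound to an amide-type nitrogen. Within the data shown here, no measured step involves an aromatic ring at this place; the step from compound 1 to compound 2 exchanges one saturated chain for another and bears only loosely on it. Compound 3 is therefore expected to sit somewhat weaker, with an estimated step of a 5.0-fold higher number from compound 1 to compound 3 (0.70 log units; beyond the scatter) and a value of 100 nM, within 25 nM to 400 nM.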

Compound 3, inhibition constant: 140 nM
Compound 3: middle estimate off by 1.4-fold (0.15 log units), on the low side; low and high end bracket the measured number.
By their numbers in this assay, from the lowest: compounds 1 and 2 (each within the scatter of the next); then compound 3.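

In this assay, the exchange of hexyl for 3,4-dimethoxyphenyl on a saturated chain carbon bound to an amide-type nitrogen gives a 7.0-fold higher number from compound 1 to compound 3 (0.85 log units; beyond the scatter), whereas the exchange of one saturated chain for another stayed within the scatter. This position therefore responds to the kind of group placed there, and not every change at the amide-type nitrogen leaves the number in place, although compound 3 still gives a measurable 140 nM in this assay. Nothing available bears on why the aromatic group gives a larger step than the saturated chains.

The compounds shown leave open whether the step belongs to the aromatic ring itself or to its methoxy groups, which a plain benzyl or a 4-methoxybenzyl at this place would separate. Also open, as far as these compounds go, is how a longer chain, or a chain ending in an amine or a carboxylic acid, would read here.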